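Swapping the amine end of the butyl chain

The source may report more compounds than this note shows. Statements on the series, on what has been measured and on what is new or still open speak of the compounds shown alone.

Measured so far:
- compound 1 `CN(C)CCCCn1c(N)c(-c2nc3ccccc3o2)c2nc(C#N)c(C#N)nc21` gives 1950 nM in a functional assay on HeLa cells (Homo sapiens) for antiproliferative activity, read by MTT assay, with a stated time of 48 h; a lower number here means a stronger inhibitor, a higher number a weaker inhibitor
- compound 2 `CCN(CC)CCCCn1c(N)c(-c2nc3ccccc3o2)c2nc(C#N)c(C#N)nc21` gives 6420 nM in this assay
- compound 3 `CN(C)CCCCn1c(N)c(-c2nc3ccccc3n2C)c2nc(C#N)c(C#N)nc21` gives 460 nM in this assay

Compound 3 stands lowest of the three, and its steps to the other two are both beyond the scatter. It differs from compound 1 in the group on the shared core, which reads (1-methyl-1H-benzimidazol-2-yl in place of 1,3-benzoxazol-2-yl on an aromatic carbon); that exchange gave a 4.2-fold lower number from compound 1 to compound 3 (0.63 log units; beyond the scatter).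

Compound 4 `CCN(CC)CCCCn1c(N)c(-c2nc3ccccc3n2C)c2nc(C#N)c(C#N)nc21` has not yet been measured. It differs from compound 3 by diethylamino in place of dimethylamino on a saturated chain carbon, four bonds along the chain from an aromatic nitrogen. The same change, at the same place in words, has already been made once, from compound 1 to compound 2, where it read diethylamino in place of dimethylamino on a saturated chain carbon, four bonds along the chain from an aromatic nitrogen and gave a 3.3-fold higher number from compound 1 to compound 2 (0.52 log units; beyond the scatter).

Within the data shown here, since the one earlier example of this change gave a modest rise in the number, compound 4 is expected to sit somewhat above compound 3, with an estimated step of a 3.3-fold higher number from compound 3 to compound 4 (0.51 log units; beyond the scatter). This expectation rests on a single precedent, so its size is uncertain. For compound 4 the estimate in this assay is 1500 nM, expected to fall between 700 nM and 3500 nM.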

Compound 4, half-maximal inhibitory concentration: 1610 nM
Beside the measured number, compound 4's estimate is 1.1-fold (0.03 log units) below it; measured number inside the range.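

In this assay, diethylamino in place of dimethylamino gave a 3.5-fold higher number from compound 3 to compound 4 (0.54 log units; beyond the scatter), and this step matches the earlier one made on the other core: the same change on two cores in this assay, a 3.3-fold higher number (0.52 log units; beyond the scatter) from compound 1 to compound 2 and a 3.5-fold higher number (0.54 log units; beyond the scatter) from compound 3 to compound 4, 1.1-fold (0.03 log units) apart, within the scatter of two such steps. The exchange of the group on the shared core behaved the same way, with 1-methyl-1H-benzimidazol-2-yl in place of 1,3-benzoxazol-2-yl giving a 4.0-fold lower number from compound 2 to compound 4 (0.60 log units; beyond the scatter), so in these four compounds each change kept its size whichever form the other part took: the same change on two cores in this assay, a 4.2-fold lower number (0.63 log units; beyond the scatter) from compound 1 to compound 3 and a 4.0-fold lower number (0.60 log units; beyond the scatter) from compound 2 to compound 4, 1.1-fold (0.03 log units) apart, within the scatter of two such steps. Among these compounds, this shows that both changes carried over between these two cores, but it rests on only two pairs for each change, and it does not show why either change acts as it does or whether it would hold on any other core.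

The compounds shown leave open how a ring amine such as pyrrolidine or morpholine at the end of the butyl chain would compare with these two amines. They also leave open what a shorter propyl chain or a longer pentyl chain would do.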